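The compounds below may be only part of what the source reports. "The series", "measured", "known", "first", "only" and "open" are said of these compounds alone.

Measured compounds in a functional assay on MCF7 cells (Homo sapiens) for cytotoxicity, read by MTT assay, with a stated time of 72 h, tested at 100 uM; a higher number here means more inhibition of growth at the concentration tested, a lower number less inhibition of growth:
Compound 1 `N/C(=N\NC(=S)N1CCOCC1)c1ccccn1` gives 81.6%.
Compound 2 `N/C(=N\NC(=S)N1CCCC1)c1ccc(F)cn1` gives 73%.
Compound 3 `N/C(=N\NC(=S)N1CCCCC1)c1ccccn1` gives 77.7%.

On these three numbers compound 3 lies between the other two, and neither gap is beyond the scatter. Going by the values given here, the only single-change step that touches it is the one from compound 1, where the change on the thiocarbonyl carbon gave a number 3.9 percentage points lower from compound 1 to compound 3 (within the scatter), a step within the scatter. Compound 2 differs from compound 3 in two places, so its value is noted only as such: a number a little under that of compound 3, again within the scatter.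

Compound 4 `N/C(=N\NC(=S)N1CCCC1)c1ccccn1` is the next member. It differs from compound 3 by pyrrolidin-1-yl in place of piperidin-1-yl on a thiocarbonyl carbon. Among the compounds with values here, no measured pair isolates this exact exchange. Within the data shown here, the one step that swapped the ring on the thiocarbonyl carbon, a number 3.9 percentage points lower from compound 1 to compound 3 (within the scatter), stayed within the scatter, and compound 2, which carries the pyrrolidin-1-yl ring together with a second change, also sits within the scatter of compound 3. On that basis no step beyond the scatter is expected in this assay for compound 4. The expected change is a number 2.7 percentage points lower from compound 3 to compound 4 (within the scatter). Compound 4 is therefore estimated at 75%, with a range from 64% to 85%.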

Compound 4, percent growth inhibition at one concentration: 74.9%
Estimate against measurement, compound 4: 0.1 percentage points above; the measured number falls inside the stated range.
By their numbers in this assay, from the lowest: compounds 2, 4, 3 and 1 (each within the scatter of the next).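

In this assay, the ring on the thiocarbonyl carbon can now be compared across three members on the same core (a number 2.8 percentage points lower from compound 3 to compound 4 (within the scatter); a number 6.7 percentage points lower from compound 1 to compound 4 (within the scatter)), and both steps stay within the scatter, so this read-out does not separate pyrrolidin-1-yl, piperidin-1-yl and morpholin-4-yl at this place. Compound 4 also isolates the fluoro group of compound 2, which until now could be seen only together with a second change, and hydrogen in place of fluoro on an aromatic carbon likewise stays within the scatter (a number 1.9 percentage points higher from compound 2 to compound 4 (within the scatter)). No supporting measurement is available to explain either result.

Still open, going by these compounds, is whether an open-chain group such as dimethylamino, or a ring such as piperazin-1-yl, on the thiocarbonyl carbon would give a step beyond the scatter, and whether chloro or methoxy on the aromatic carbon would do so. On these data alone, all these readings come from a single concentration, so how the compounds would separate at lower concentrations remains unknown.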